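The compounds below may be only part of what the source reports. "The series", "measured", "known", "first", "only" and "open" are said of these compounds alone.

Measured in a functional assay on HT-29 cells (Homo sapiens) for inhibition, read by luminescence and CellTiter-Glo, with a stated time of 24 h; on this read-out higher numbers stand for an effect only at larger amounts of compound and lower numbers for an effect already at smaller amounts:
- compound 1 `CN1C(=S)[C@@H](NC(=O)c2nc(Cc3ccccc3)n(CCCC#N)n2)COc2ccccc21`: 2400 nM
- compound 2 `CN1C(=S)[C@@H](NC(=O)c2nc(Cc3ccccc3)n(C3CCCC3)n2)COc2ccccc21`: 3530 nM
- compound 3 `CN1C(=S)[C@@H](NC(=O)c2nc(Cc3ccccc3)n(C3CCCCCC3)n2)COc2ccccc21`: 5530 nM

Compound 3, at 5530 nM, marks the upper end of these numbers and shares that end with compound 2: a 1.6-fold higher number from compound 2 to compound 3 (0.19 log units; within the scatter). Only the gap to compound 1 is larger: a 2.3-fold higher number from compound 1 to compound 3 (0.36 log units; beyond the scatter).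

Compound 4 `CN1C(=S)[C@@H](NC(=O)c2nc(Cc3ccccc3)n(C3CCOC3)n2)COc2ccccc21` carries oxolan-3-yl in place of cycloheptyl on an aromatic nitrogen. Among the measured compounds shown here, no measured compound has a ring with a hetero atom at this place, so the oxygen itself is untested.

The nearest guide is the exchange of substituents on the same nitrogen, which has moved the numbers only modestly: a 1.5-fold higher number from compound 1 to compound 2 (0.17 log units; within the scatter). Compound 2, with its five-membered non-aromatic ring, stands at 3530 nM, so a value near it is expected in this assay.

The expected step is small, towards a lower number and not beyond the scatter: a 1.7-fold lower number from compound 3 to compound 4 (0.24 log units; within the scatter).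

For compound 4 the estimated value is 3200 nM, with an expected range of 1400 nM to 7500 nM.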

Compound 4, half-maximal effective concentration: 1580 nM
The estimate for compound 4 lay 2.0-fold (0.31 log units) above the measured number; measured number inside the range.
By their numbers in this assay, from the lowest: compounds 4, 1, 2 and 3 (each within the scatter of the next, the first and the last beyond it).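

On the aromatic nitrogen in this assay, oxolan-3-yl separates from both carbon-only rings, (a 3.5-fold lower number from compound 3 to compound 4 (0.54 log units; beyond the scatter)) and (a 2.2-fold lower number from compound 2 to compound 4 (0.35 log units; beyond the scatter)), whereas those two rings stay within the scatter of each other. The step from compound 2 keeps the five-membered non-aromatic ring and exchanges carbon-only for one oxygen, so a hetero atom in a ring of this size is tolerated here and goes with a lower number. Compound 4 nevertheless stays level with the open-chain compound 1 (a 1.5-fold lower number from compound 1 to compound 4 (0.18 log units; within the scatter)), and no evidence on the cause of these steps is at hand.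

From the compounds shown here alone, with a single hetero-atom ring, it remains open whether the oxygen itself carries the step or whether it extends to other rings. Oxan-4-yl, pyrrolidin-3-yl or a piperidine ring at this nitrogen would test that.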